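The source may hold more compounds than are shown below. What is called first, only, known or untested is meant among the compounds shown, and "the series" means these compounds.

Compound 1 `OC[C@H]1O[C@@H](n2cnc3c(NCc4ccccc4Br)ncnc32)[C@H](O)[C@@H]1O` in a functional assay on HOS cells (Homo sapiens) for antiproliferative activity, with a stated time of 72 h (a higher number here means a weaker inhibitor, a lower number a stronger inhibitor), gives > 166000 nM, which is a limit of the assay.
Compound 2 `Cc1cccc(CNc2ncnc3c2ncn3[C@@H]2O[C@H](CO)[C@@H](O)[C@H]2O)c1` in this assay gives > 166000 nM, likewise a limit.
Compound 3 `COc1cccc(CNc2ncnc3c2ncn3[C@@H]2O[C@H](CO)[C@@H](O)[C@H]2O)c1O` in this assay gives > 166000 nM, again a limit.

Compound 2 therefore stands only at a limit, not at a number, and compound 4 `Cc1ccc(O)c(CNc2ncnc3c2ncn3[C@@H]2O[C@H](CO)[C@@H](O)[C@H]2O)c1` is the compound to be measured. It differs from compound 2 in one place: hydroxy in place of hydrogen on an aromatic carbon. The measured steps that touch the same benzyl group are a step that the two limits leave unreadable from compound 1 to compound 2, a step that the two limits leave unreadable from compound 1 to compound 3 and a step that the two limits leave unreadable from compound 2 to compound 3, none of which can be read because of the limit of > 166000 nM in this assay, at which 3 of the 3 values shown sit. No readable step exists that bears on the change to compound 4, so no direction can be taken from the series. Compound 4 is expected at 200000 nM, within 50000 nM to 1000000 nM, most probably again as a limit. The step expected is a step that the limit leaves unreadable from compound 2 to compound 4.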

Compound 4, half-maximal inhibitory concentration: > 166000 nM
Compound 4 ended at the assay's limit (the forecaster's own chance of this, stated with the estimate: 85%); the middle value is on the limit's open side.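

Compound 4 gives no readable step against compound 1, compound 2 or compound 3, all steps being lost to the limit: the limit of > 166000 nM in this assay, at which 4 of the 4 values shown sit.

The compounds shown leave open whether any benzyl group on the shared core gives a numerical value in this assay.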